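Phenyl for allyl on a ring nitrogen and paw edema

The source may report more compounds than this note shows. Statements on the series, on what has been measured and on what is new or still open speak of the compounds shown alone.

Of the compounds shown here, three have been measured in a functional assay on the whole organism (strain albino) for inhibition, with Rattus norvegicus as the target, read by paw edema, with a stated time of 4 h, at a dose of 0.28 mmol/kg by the oral route; on this read-out higher numbers stand for more inhibition at the one dose given (going by the name of the read-out) and lower numbers for less inhibition. Compound 1 `COc1ccc(-c2nnc(SC/C(=N/O)c3ccccc3)n2-c2ccccc2)cc1` gives 80%, compound 2 `C=CCn1c(SC/C(=N/O)c2ccccc2)nnc1-c1ccc(OC)cc1` gives 76%, and compound 3 `C=CCn1c(SCC(=O)c2ccccc2)nnc1-c1cc(OC)c(OC)c(OC)c1` gives 66%. Compound 2 and compound 1 differ in one place, (phenyl in place of allyl on an aromatic nitrogen), and that exchange made a number 4 percentage points higher from compound 2 to compound 1 (within the scatter). Compound 4 `COc1cc(-c2nnc(SCC(=O)c3ccccc3)n2-c2ccccc2)cc(OC)c1OC` is not yet measured; it differs from compound 3 by the same kind of change, (phenyl in place of allyl on an aromatic nitrogen), the place differing in that the ring atom next to it bears a (benzoylmethyl)sulfanyl group rather than a 4-methoxyphenyl group. The difference between the core of compound 3 and that of compound 2 is not broken down here. Resting on a number 4 percentage points higher from compound 2 to compound 1 (within the scatter), compound 4 is expected to show a number 4 percentage points higher from compound 3 to compound 4 (within the scatter). In this assay compound 4 is therefore estimated at 70%, with a likely range from 58% to 82%.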

Compound 4, a percentage reported as inhibition, in the whole organism at one dose (the size of the read-out at that dose, not a potency): 73%
Compound 4: middle estimate off by 3 percentage points, on the low side; low and high end bracket the measured number.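

In this assay, phenyl in place of allyl on the aromatic nitrogen made a number 7 percentage points higher from compound 3 to compound 4 (within the scatter). Set beside the earlier exchange, the two steps agree: the same change on two cores in this assay, a number 4 percentage points higher (within the scatter) from compound 2 to compound 1 and a number 7 percentage points higher (within the scatter) from compound 3 to compound 4, 3 percentage points apart, within the scatter of two such steps. On these two cores the exchange therefore carries over without a visible difference, but with both steps within the scatter, this does not show that phenyl gives more inhibition than allyl on either core, and it says nothing about any other core in the series.

The compounds shown leave open what a methyl, a benzyl or a longer chain would do on that ring nitrogen. They also leave open whether the exchange would carry over to a core bearing an amine or a carboxylic acid.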